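Trimethoxystyryl thienopyrimidine: arylamino replaces pyrrolidine

A few compounds are considered here, and "the series" means these few. Any claim that something is new, unique, unknown or untested is made for them only; others in the source may bear on it.

Measured compounds:
compound 1 `CCCc1nn(C)c2c(NC3CC3)nc(/C=C/c3nc(C)c(C)nc3C)nc12` gives 706000 nM
compound 2 `Brc1cccc(Nc2nc(/C=C/c3ccccc3)nc3ccsc23)c1` gives > 1000000 nM
compound 3 `COc1cc(/C=C/c2nc(N3CCCC3)c3sccc3n2)cc(OC)c1OC` gives 681000 nM

Of the compounds shown here, three have been measured in a functional assay on L02 cells (Homo sapiens) for inhibition, read by Griess assay, with stated times of 1 h and 24 h; a lower number here means a stronger inhibitor, a higher number a weaker inhibitor. Compound 1 `CCCc1nn(C)c2c(NC3CC3)nc(/C=C/c3nc(C)c(C)nc3C)nc12` gives 706000 nM in this assay. Compound 3 `COc1cc(/C=C/c2nc(N3CCCC3)c3sccc3n2)cc(OC)c1OC` gives 681000 nM in this assay. Compound 2 `Brc1cccc(Nc2nc(/C=C/c3ccccc3)nc3ccsc23)c1` does not give a number: its value in this assay is a limit, > 1000000 nM. Of the three values shown, one sits at the limit of > 1000000 nM in this assay, at which 1 of the 3 values shown sits.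

Compound 3 therefore holds the lowest of the two numbers, and the nearest number, that of compound 1, lies within the scatter of it, so the two cannot be told apart on these data.

Compound 4 `COc1cc(/C=C/c2nc(Nc3ccc(C(C)C)cc3)c3sccc3n2)cc(OC)c1OC` has not yet been measured in this assay. It differs from compound 3 in one place: (4-isopropylphenyl)amino in place of pyrrolidin-1-yl on an aromatic carbon. Among the compounds with values here, no step between measured compounds that differ in a single place is available, so the size of this step cannot be read from a precedent. Given that the measured numbers are all weak and close to the limit, the step is expected to be small and without a clear direction, so the expected step is a 1.2-fold higher number from compound 3 to compound 4 (0.10 log units; within the scatter), not beyond the scatter. Compound 4 is expected to give about 850000 nM in this assay, within a range from 300000 nM to 2500000 nM.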

Compound 4, half-maximal inhibitory concentration: 370000 nM
The estimate for compound 4 lay 2.3-fold (0.36 log units) above the measured number; the range from low to high includes it.
By their numbers in this assay, from the lowest: compounds 4, 3 and 1 (each within the scatter of the next). At a limit, above all of these: compound 2.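

In this assay, exchanging pyrrolidin-1-yl for (4-isopropylphenyl)amino on the aromatic carbon next to the ring nitrogen gives a 1.8-fold lower number from compound 3 to compound 4 (0.26 log units; within the scatter), the first step shown at this position between two compounds that differ in one place. The entering group brings a six-membered aromatic ring of carbon only and a hydrogen-bond donor that pyrrolidin-1-yl lacks, yet this large change of group leaves the two numbers indistinguishable, so neither feature is shown here to matter at this position. Compound 2 has a limit and not a number, and it gives no step: the limit of > 1000000 nM in this assay, at which 1 of the 4 values shown sits.

The compounds shown leave open whether any group at this position can move the number beyond the scatter, whether a small primary amine, a morpholin-4-yl or an anilino group bearing a carboxylic acid in place of the isopropyl would do so. Within the data shown here, they also leave open whether the same exchange would behave alike with other groups on the styryl arm, since this one step is the only precedent.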